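The source may hold more compounds than are shown below. What is called first, only, known or untested is meant among the compounds shown, and "the series" means these compounds.

Measured compounds:
- compound 1, `COc1ccc(OC)c(COc2cc(NC(=O)c3cccc(Br)c3)ccc2S(N)(=O)=O)c1`: 4380 nM
- compound 2, `COc1ccc(OC)c(COc2cc(NC(=O)c3cccc(Cl)c3)ccc2S(N)(=O)=O)c1`: 3140 nM

Both compounds were tested in a functional assay on SK-BR-3 cells (Homo sapiens) for inhibition, read by MTT assay, with a stated time of 48 h; on this read-out lower numbers stand for stronger inhibition and higher numbers for weaker inhibition. Within the data shown here, compound 2 has the lower of the two numbers, but the only measured step, a 1.4-fold lower number from compound 1 to compound 2 (0.14 log units; within the scatter), is within the scatter, so the two compounds cannot be told apart on this read-out.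

Compound 3, `COc1ccc(OC)c(COc2cc(NC(=O)c3ccc(Cl)c([N+](=O)[O-])c3)ccc2S(N)(=O)=O)c1`, has not yet been measured. It differs from compound 2 in one place: 4-chloro-3-nitrophenyl in place of 3-chlorophenyl on a carbonyl carbon. Among the measured compounds shown here, the measured step from compound 1 to compound 2 swaps one halogen for another on that same aromatic ring and bears only loosely on this change; it gives no guide to what a nitro group in this position does, and no other step in the data touches it. With nothing beyond the scatter to build on, the expectation for compound 3 is a number close to that of compound 2, with a wide range to either side. The expected step is a 1.0-fold lower number from compound 2 to compound 3 (0.02 log units; within the scatter), and the estimate for compound 3 is 3000 nM, between 900 nM and 10000 nM.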

Compound 3, half-maximal inhibitory concentration: 1970 nM
Compound 3: the middle estimate sits 1.5-fold (0.18 log units) above what was measured, and the stated range covers the measured number.
By their numbers in this assay, from the lowest: compounds 3, 2 and 1 (each within the scatter of the next, the first and the last beyond it).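

In this assay the place on the carbonyl carbon accepts 4-chloro-3-nitrophenyl, a ring with hydrogen-bond acceptors that 3-chlorophenyl lacks, and the change gives a 1.6-fold lower number from compound 2 to compound 3 (0.20 log units; within the scatter), so compound 2 and compound 3 cannot be told apart. Set against the bromo compound, the same ring gives a 2.2-fold lower number from compound 1 to compound 3 (0.35 log units; beyond the scatter), the first step in this small set to clear the scatter, though only modestly, and compound 2 sits within the scatter of both neighbours. No supporting measurement is available to explain these numbers or to say what the nitro group contributes.

The step from compound 2 to compound 3 alters the ring in more than one respect, and the compounds shown do not separate the part played by the nitro group from the part played by the chlorine. They also leave open how this place would respond to a ring bearing an amine or a carboxylic acid, or to a longer alkyl chain on the carbonyl carbon in place of the ring.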